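The source may report more compounds than this note shows. Statements on the series, on what has been measured and on what is new or still open speak of the compounds shown alone.

Measured so far in a functional assay on BGC-823 cells (Homo sapiens) for inhibition, read by MTT assay, with a stated time of 72 h; on this read-out higher numbers stand for weaker inhibition and lower numbers for stronger inhibition:

Compound 1 `Cc1ccc(N2CCCC2)c(C(=O)Nc2ccc(CNC(=O)OCc3cccnc3)cc2)c1` gives > 100000 nM, which is a limit of this assay and not a number.
Compound 2 `O=C(NCc1ccc(NC(=O)c2cccc(F)c2N2CCCC2)cc1)OCc1cccnc1` gives > 100000 nM, again a limit of this assay.
Compound 3 `O=C(NCc1ccc(NC(=O)c2cc(F)ccc2N2CCCC2)cc1)OCc1cccnc1` gives 14800 nM.

Compound 3 is the only one of the three with a measured number. The step to compound 1 is an at least 6.7-fold higher number from compound 3 to compound 1 (0.82 log units; beyond the scatter), the change being (methyl in place of fluoro on an aromatic carbon). Compound 2 shares its atoms with compound 3 but joins them differently; the difference between the two cores is not broken down here.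

Compound 4 `Cc1cccc(C(=O)Nc2ccc(CNC(=O)OCc3cccnc3)cc2)c1N1CCCC1` is not yet measured. It differs from compound 2 by methyl in place of fluoro on an aromatic carbon. This is the same kind of change as that from compound 3 to compound 1, but not the same: there the methyl stands meta to a large group and para to a pyrrolidin-1-yl group, whereas here it stands ortho to a pyrrolidin-1-yl group and meta to a large group.

The measured step of this kind runs toward weaker inhibition, and compound 2 already sits at the limit of > 100000 nM in this assay, at which 2 of the 3 values shown sit, so no number for a step from compound 2 can be computed. Compound 4 is therefore expected to stay at or beyond that limit, with an expected step that the limit leaves unreadable from compound 2 to compound 4. Compound 4 is estimated at 150000 nM, between 40000 nM and 600000 nM, most likely reported only as a limit.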

Compound 4, half-maximal inhibitory concentration: > 100000 nM
Compound 4 was reported as a limit; the forecaster's own chance of this, stated with the estimate: 80%; the middle value lies beyond the limit too.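

In this assay compound 4 gives > 100000 nM, a limit and not a number. Compound 2 also stands at a limit, so no step can be read from compound 2 to compound 4: the limit of > 100000 nM in this assay, at which 3 of the 4 values shown sit.

The compounds shown leave open how far compound 2 and compound 4 lie beyond the limit, and whether methyl in place of fluoro ortho to a pyrrolidin-1-yl group changes inhibition at all.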